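Removing a Naphthyl Group from a Potent Sulfonamide

This account rests on a few compounds, and the source may have more. Where it says the series, first, only, none or still open, it means among the compounds named here.

Of the compounds shown here, two have been measured in a functional assay on DLD-1 cells (Homo sapiens) for antiproliferative activity, read by CellTiter-Glo, with a stated time of 72 h; on this read-out lower numbers stand for stronger inhibition and higher numbers for weaker inhibition. Compound 1, with the structure `CCc1ccc(S(=O)(=O)N2CCC(N3CCC(C)CC3)CC2)cc1`, gives only a limit in this assay, > 5000 nM, so no number is known for it. Compound 2, with the structure `CC1CCN(C2CCN(S(=O)(=O)c3cccc(-c4ccc5ccccc5c4)c3)CC2)CC1`, gives 2 nM in this assay, which is the only number shown. Compound 3, with the structure `CC1CCN(C2CCN(S(=O)(=O)c3cccc(Cl)c3)CC2)CC1`, has not yet been measured. It differs from compound 2 in one place: chloro in place of naphthalen-2-yl on an aromatic carbon. Compound 1 also lacks the naphthalen-2-yl group, and it sits at the limit, as the limit of > 5000 nM in this assay, at which 1 of the 2 values shown sits, records. Among the measured compounds shown here, since the one compound without the naphthalen-2-yl group reaches only a limit while compound 2 is strongly active, the step is expected to be a large loss of activity, far beyond the usual scatter, so that a 750-fold higher number from compound 2 to compound 3 (2.88 log units; beyond the scatter) is the expected change. Compound 3 is accordingly estimated at 1500 nM, with a likely range from 150 nM to 5000 nM, and a real chance that this assay reports only a limit.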

Compound 3, half-maximal inhibitory concentration: > 5000 nM
Compound 3 gave a limit, no number; the forecaster's own chance of this, stated with the estimate: 40%; middle value at least 3.3-fold (0.52 log units) from the limit.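

In this assay, replacing naphthalen-2-yl with chloro on the same aromatic carbon, with the rest of the molecule unchanged, gives an at least 2500-fold higher number from compound 2 to compound 3 (3.39 log units; beyond the scatter). Among the compounds shown here, compound 1 also lacks the naphthalen-2-yl group, but it differs from compound 2 in more than one place, so it could not tie the loss to this group alone; the single change in compound 3 does, and it shows that a chloro at this position does not keep the activity of compound 2. Compound 3 stops at a limit of the assay and not at a number, so the step gives only the smallest possible size of the loss, and the compound shares its result with compound 1: the limit of > 5000 nM in this assay, at which 2 of the 3 values shown sit.

The step between compound 1 and compound 3 cannot be read, as both values are limits, so nothing ranks these two compounds against each other. On these data alone, whether a phenyl ring, a methoxy group or an amine on this aromatic carbon would keep some of the activity remains open, and so does how much of the naphthalen-2-yl group is needed for it.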